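The source may hold more compounds than are shown below. What is called first, only, known or untested is meant among the compounds shown, and "the series" means these compounds.

Compound 1 `ClCc1ccccc1Cn1cnc2c(Cl)nc(Cl)nc21`, compound 2 `ClCc1ccccc1Cn1cnc2c(Cl)ncnc21` and compound 3 `ClCc1cccc(Cn2cnc3ncnc(Cl)c32)c1` have been tested in a functional assay on IGROV-1 cells (Homo sapiens) for cytotoxicity, read by sulforhodamine B assay, with a stated time of 48 h; a higher number here means a weaker inhibitor of growth, a lower number a stronger inhibitor of growth. Compound 1 gives 1540 nM, compound 2 gives 3160 nM, and compound 3 gives 3380 nM. Compound 2 and compound 3 are built from the same atoms joined differently; the difference between the two cores is not broken down here, and their values lie within the scatter of each other. Compound 1 arises from compound 2 by chloro in place of hydrogen on an aromatic carbon, a change that gave a 2.1-fold lower number from compound 2 to compound 1 (0.31 log units; beyond the scatter). Compound 4 `ClCc1cccc(Cn2cnc3nc(Cl)nc(Cl)c32)c1` arises from compound 3 by chloro in place of hydrogen on an aromatic carbon, the same change at the same kind of place. Because compound 2 to compound 1 showed a 2.1-fold lower number from compound 2 to compound 1 (0.31 log units; beyond the scatter), a step of similar size, a 2.0-fold lower number from compound 3 to compound 4 (0.31 log units; beyond the scatter), is expected for compound 4. On this basis compound 4 is estimated at 1650 nM, likely between 900 nM and 3200 nM in this assay.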

Compound 4, concentration for 50% growth inhibition: 17000 nM
Beside the measured number, compound 4's estimate is 10-fold (1.01 log units) below it, outside the stated range (above it).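

In this assay, chloro in place of hydrogen on an aromatic carbon gave a 5.0-fold higher number from compound 3 to compound 4 (0.70 log units; beyond the scatter), so compound 4 became a weaker inhibitor of growth where compound 1 had become a stronger one. The change therefore did not carry from one core to the other with the same direction or size: the same change on two cores in this assay, a 2.1-fold lower number (0.31 log units; beyond the scatter) from compound 2 to compound 1 and a 5.0-fold higher number (0.70 log units; beyond the scatter) from compound 3 to compound 4, 10-fold (1.01 log units) apart, beyond the scatter of two such steps This rests on a single pair from each core, so it shows that the outcome depends on the core here but neither explains the difference nor predicts the result on any further core.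

The compounds shown leave open how an amine or a methoxy group would behave at this place, between two ring nitrogen atoms. They also leave open whether either group would respond differently on the two cores.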